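Swapping the Pendant Phenyl Ring on a Thiourea Analogue

This account rests on a few compounds, and the source may have more. Where it says the series, first, only, none or still open, it means among the compounds named here.

Measured compounds:
compound 1, `COc1cc(/C=C/C(=O)C2=C(/C=C/c3ccc(O)c(OC)c3)NC(=O)NC2c2ccccc2O)ccc1O`: 73.6%
compound 2, `COc1cc(/C=C/C(=O)C2=C(/C=C/c3ccc(O)c(OC)c3)NC(=O)NC2c2ccc(N(C)C)cc2)ccc1O`: 37.6%
compound 3, `COc1cc(/C=C/C(=O)C2=C(/C=C/c3ccc(O)c(OC)c3)NC(=S)NC2c2ccccc2O)ccc1O`: 60.2%

In a functional assay, with a stated time of 20 min, tested at 10 uM (a higher number here means a stronger effect of the compound at the concentration tested, a lower number a weaker effect), compound 1 gives the highest of the three numbers. One change, (4-(dimethylamino)phenyl in place of 2-hydroxyphenyl on a saturated ring carbon), turns compound 1 into compound 2, and this assay shows a number 36 percentage points lower from compound 1 to compound 2 (beyond the scatter). Compound 3 shares the core of compound 1 except in a part that is not broken down here; in this assay compound 3 sits lower than compound 1 and higher than compound 2, both gaps lying beyond the usual scatter.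

Compound 4, `COc1cc(/C=C/C(=O)C2=C(/C=C/c3ccc(O)c(OC)c3)NC(=S)NC2c2ccc(N(C)C)cc2)ccc1O`, is the unmeasured member. For the measured compounds named here, it arises from compound 3 by 4-(dimethylamino)phenyl in place of 2-hydroxyphenyl on a saturated ring carbon, the same change at the same place as the one that separates compound 1 from compound 2. Going by the values given here, only one such step has been measured, so it is the single guide. Resting on the measured step of a number 36 percentage points lower from compound 1 to compound 2 (beyond the scatter), the expected step is a number 33.2 percentage points lower from compound 3 to compound 4 (beyond the scatter), a drop of a similar size starting from the lower number of compound 3. Compound 4 is therefore estimated to give 27%, most likely between 10% and 46%.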

Compound 4, a percentage reported as activity, at one concentration (the size of the read-out at that concentration, not a potency): 72%
Compound 4: middle estimate off by 45 percentage points, on the low side; measured number outside the range, above it.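

In this assay, putting 4-(dimethylamino)phenyl in place of 2-hydroxyphenyl gives a number 11.8 percentage points higher from compound 3 to compound 4 (beyond the scatter) and so does not lower the read-out on this core. Set beside the earlier step, the same change does not carry over from one core to the other, in either size or direction: the same change on two cores in this assay, a number 36 percentage points lower (beyond the scatter) from compound 1 to compound 2 and a number 11.8 percentage points higher (beyond the scatter) from compound 3 to compound 4, 47.8 percentage points apart, beyond the scatter of two such steps. This shows that, among these four compounds, the result of the change cannot be assumed to transfer between the two cores, but it does not show why the steps differ, and one pair on each core gives no rule for any other core.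

On these data alone, whether the reversal would also appear with another group on that saturated ring carbon, such as a plain phenyl, a carboxylic acid or an amine on a longer chain, stays open. Also open, as far as these compounds go, is whether the same reversal holds at other concentrations, as each read-out comes from a single concentration.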